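Fluoro on the benzamido ring: expectation for compound 3

The compounds below may be only part of what the source reports. "The series", "measured", "known", "first", "only" and "open" are said of these compounds alone.

Measured so far in a functional assay on Raji cells (Homo sapiens) for antiproliferative activity, read by CCK-8 assay, with a stated time of 72 h, tested at 40 uM; a higher number here means more inhibition at the concentration tested (going by the name of the read-out), a lower number less inhibition:
compound 1 `CN1CCN(c2ccc(Nc3nc(-c4cccc(NC(=O)c5ccc(C(F)(F)F)cc5)c4)sc3C(N)=O)cc2)CC1`: 91.9%
compound 2 `CN1CCN(c2ccc(Nc3nc(-c4cccc(NC(=O)c5ccccc5)c4)sc3C(N)=O)cc2)CC1`: 91.3%

Compound 2 stands lowest of the two numbers in this assay; the nearest is compound 1, whose number is higher only within the scatter. For the measured compounds named here, the single measured step, a number 0.6 percentage points lower from compound 1 to compound 2 (within the scatter), arises from hydrogen in place of trifluoromethyl on an aromatic carbon of the benzoyl ring, and it lies within the scatter.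

Compound 3 `CN1CCN(c2ccc(Nc3nc(-c4cccc(NC(=O)c5ccccc5F)c4)sc3C(N)=O)cc2)CC1` is the next member; it differs from compound 2 by fluoro in place of hydrogen on an aromatic carbon. Going by the values given here, the only step that bears on it is the one from compound 1 to compound 2, which also alters a substituent on the same benzoyl ring and left the read-out essentially unchanged. On that basis no step beyond the scatter is expected in this assay for compound 3, in either direction.

For compound 3 the estimate is 90%, with a range from 78% to 97%. The expected step for compound 3 is therefore a number 1.3 percentage points lower from compound 2 to compound 3 (within the scatter).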

Compound 3, a percentage reported as inhibition, at one concentration (the size of the read-out at that concentration, not a potency): 97.3%
Compound 3: middle estimate off by 7.3 percentage points, on the low side, and the stated range ends below it.
By their numbers in this assay, from the lowest: compounds 2, 1 and 3 (each within the scatter of the next).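

In this assay, fluoro on an aromatic carbon ortho to a large group gives a number 6 percentage points higher from compound 2 to compound 3 (within the scatter) and so adds no step beyond the scatter at this place on the benzoyl ring. The exchange of 4-(trifluoromethyl)phenyl for 2-fluorophenyl on the carbonyl carbon gives a number 5.4 percentage points higher from compound 1 to compound 3 (within the scatter) and is likewise not separable from the scatter, so the three benzoyl variants cannot be ranked in this read-out. No measurement on hand bears on why the read-out stays where it does.

From the compounds shown here alone, whether an amine, a methoxy group or a carboxylic acid on this same aromatic carbon would give a step beyond the scatter stays open, as does the effect of a larger group such as a longer chain there. All three compounds read high in this assay at a single concentration, which leaves open whether they would separate in a potency measurement across several concentrations.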